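Ethoxycarbonyl in place of methyl on the piperidine ring

The source may hold more compounds than are shown below. What is called first, only, known or untested is meant among the compounds shown, and "the series" means these compounds.

Measured so far:
compound 1 `CC1CCCN(C(=O)CN2CN(c3ccccc3)C3(CCN(C(=O)c4ccc(C5CCCCC5)cc4)CC3)C2=O)C1`: 3600 nM
compound 2 `CC1CCCN(C(=O)CN2CN(c3ccccc3)C3(CCN(C(=O)c4ccc(C(C)(C)C)cc4)CC3)C2=O)C1`: 12000 nM
compound 3 `CC(C)(C)c1ccc(C(=O)N2CCC3(CC2)C(=O)N(CC(=O)N2CCCC(CO)C2)CN3c2ccccc2)cc1`: 8200 nM

All three were tested in an assay on HEK293 cells for displacement of a labelled ligand from NPC1-like intracellular cholesterol transporter 1 (Homo sapiens); a higher number here means a weaker inhibitor, a lower number a stronger inhibitor. Compound 1 gives the lowest number of the three, ahead of compound 3 and compound 2, both beyond the scatter. Compound 4 `CCOC(=O)C1CCCN(C(=O)CN2CN(c3ccccc3)C3(CCN(C(=O)c4ccc(C5CCCCC5)cc4)CC3)C2=O)C1` differs from compound 1 in one place: ethoxycarbonyl in place of methyl on a saturated ring carbon.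

Among the compounds with values here, only one measured step touches this ring: a 1.5-fold lower number from compound 2 to compound 3 (0.17 log units; within the scatter), which stayed within the scatter. The step of a 3.3-fold higher number from compound 1 to compound 2 (0.52 log units; beyond the scatter) concerns the aromatic part and does not bear on this change. A change at this position is therefore expected to move the number little, if at all, beyond the scatter. Compound 4 is estimated at 4000 nM, between 1500 nM and 11000 nM, meaning an expected 1.1-fold higher number from compound 1 to compound 4 (0.05 log units; within the scatter).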

Compound 4, half-maximal inhibitory concentration: 4200 nM
The estimate for compound 4 lay 1.1-fold (0.02 log units) below the measured number, and the stated range covers the measured number.
By their numbers in this assay, from the lowest: compounds 1, 4, 3 and 2 (each within the scatter of the next, the first and the last beyond it).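

The step of a 1.2-fold higher number from compound 1 to compound 4 (0.07 log units; within the scatter) comes with methyl replaced by ethoxycarbonyl, which has 5 heavy atoms and 2 hydrogen-bond acceptors against 1 heavy atom and none. Within the data shown here, this ring carbon, two ring bonds from the ring nitrogen, therefore takes a much larger group than the earlier compounds carried there, with no shift beyond the scatter. No measurement here explains this result.

As far as these compounds go, whether a carboxylic acid or an amine at this ring carbon would behave the same remains open. So does whether ethoxycarbonyl gives the same result with tert-butyl in place of cyclohexyl.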